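Compound 2 to compound 3: a longer side chain

The source may hold more compounds than are shown below. What is called first, only, known or untested is meant among the compounds shown, and "the series" means these compounds.

Measured so far in a functional assay on A549 cells (Homo sapiens) for cytotoxicity, read by MTT assay, with a stated time of 72 h (on this read-out lower numbers stand for stronger inhibition and higher numbers for weaker inhibition), for two compounds:
- Compound 1 `O=C1c2c[n+]([O-])c3ccccc3c2C(=O)c2c1c1ccccc1n2Cc1cn(C[C@H](O)CO)nn1` gives 1030 nM here
- Compound 2 `O=C1c2c[n+]([O-])c3ccccc3c2C(=O)c2c1c1ccccc1n2CCN1CCCC1` gives 410 nM here

Compound 2 holds the lower of these two numbers, so it is the stronger of the pair. Among the compounds with values here, compound 3 `O=C1c2c[n+]([O-])c3ccccc3c2C(=O)c2c1c1ccccc1n2CCCCN1CCCCC1` is still unmeasured. 2-(piperidin-1-yl)ethyl in place of pyrrolidin-1-yl on a saturated chain carbon, two bonds along the chain from an aromatic nitrogen is its change from compound 2: 2-(piperidin-1-yl)ethyl in place of pyrrolidin-1-yl on a saturated chain carbon, two bonds along the chain from an aromatic nitrogen. a 2.5-fold lower number from compound 1 to compound 2 (0.40 log units; beyond the scatter) is the only measured step that bears on this, a modest one at the same side chain. It cannot show a direction for the new change, so no step beyond the scatter is expected in this assay for this pair. The estimate means a 1.2-fold lower number from compound 2 to compound 3 (0.07 log units; within the scatter) as the expected step. Compound 3 is estimated at 350 nM with 120 nM to 1000 nM as the expected range.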

Compound 3, half-maximal inhibitory concentration: 150 nM
Compound 3: middle estimate off by 2.3-fold (0.37 log units), on the high side, and the stated range covers the measured number.
By their numbers in this assay, from the lowest: compound 3; then compound 2; then compound 1.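

In this assay, moving to 4-(piperidin-1-yl)butyl on the aromatic nitrogen gives a 2.7-fold lower number from compound 2 to compound 3 (0.44 log units; beyond the scatter), so this position still responds after the 2-(pyrrolidin-1-yl)ethyl chain of compound 2 is changed. Against the triazole chain, the overall difference grows to a 6.9-fold lower number from compound 1 to compound 3 (0.84 log units; beyond the scatter). No measurement here offers an explanation for either step.

The chain and the ring changed together, so the compounds shown leave open which of the two matters. A 4-(pyrrolidin-1-yl)butyl chain would separate them, and a morpholine ring at the chain end would show whether the ring's carbon-only remainder is needed.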